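The compounds below may be only part of what the source reports. "The series", "measured", "known", "first", "only" and "open" are said of these compounds alone.

Working notes on the series. In a functional assay on HL-60 cells (Homo sapiens) for cytotoxicity, read by WST assay, with a stated time of 48 h (a lower number here means that less compound is needed, a higher number that more compound is needed for the effect), compound 1 `Cc1ccccc1C[C@H]1C(=O)OC[C@@H]1Cc1ccccc1` gives 57000 nM, and compound 2 `Cc1cccc(C[C@H]2C(=O)OC[C@@H]2Cc2ccccc2)c1` gives 53000 nM. Compound 3 `O=C1OC[C@H](Cc2ccccc2)[C@H]1Cc1ccc(O)cc1`, which carries the 4-hydroxyphenyl group, gives 88000 nM. Compound 3 stands within the scatter of both other compounds, with a 1.5-fold higher number from compound 1 to compound 3 (0.19 log units; within the scatter) and a 1.7-fold higher number from compound 2 to compound 3 (0.22 log units; within the scatter). The remaining pair shows a 1.1-fold lower number from compound 1 to compound 2 (0.03 log units; within the scatter), so the three values form one group with no order among them.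

The next change leads to compound 4 `CCCCOc1ccc(C[C@H]2C(=O)OC[C@@H]2Cc2ccccc2)cc1`, in which hydroxy goes to butoxy: butyl in place of hydrogen on an oxygen on an aromatic ring. This places butyl in place of hydrogen on an oxygen on an aromatic ring.

The measured steps bear on this change only indirectly. All of them exchange one substituted phenyl group for another on the same saturated chain carbon, and none puts a chain on that oxygen. The largest of them is a 1.7-fold higher number from compound 2 to compound 3 (0.22 log units; within the scatter), so in this assay no step beyond the scatter is expected. Among the measured compounds shown here, no measured compound carries a butyl group, so the range is kept wide. The expected step is a 1.8-fold lower number from compound 3 to compound 4 (0.25 log units; within the scatter), and this remains an estimate. For compound 4 the estimated value is 50000 nM, with an expected range of 15000 nM to 120000 nM.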

Compound 4, half-maximal effective concentration: 23000 nM
The estimate for compound 4 lay 2.2-fold (0.34 log units) above the measured number, within the range that was stated.
By their numbers in this assay, from the lowest: compound 4; then compounds 2, 1 and 3 (each within the scatter of the next).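

In this assay, among the compounds shown here, a 3.8-fold lower number from compound 3 to compound 4 (0.58 log units; beyond the scatter) is the first step to lie beyond the scatter, although its size is modest. Earlier steps only exchanged one substituted phenyl group for another on the saturated chain carbon and all stayed within the scatter, whereas this one shows that the number can respond to butyl in place of hydrogen on an oxygen on an aromatic ring. No measurement shown gives a reason for this step.

For the compounds shown here, the series holds only this one change on that oxygen, so it leaves open whether the step follows the loss of the hydrogen or the presence of the butyl chain, and a methyl group or a longer chain such as hexyl on the same oxygen would separate the two. On these data alone, it is also open how the number would respond to an amine or a carboxylic acid at the end of such a chain, and whether any chain on that oxygen would carry the step further.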